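This account rests on a few compounds, and the source may have more. Where it says the series, first, only, none or still open, it means among the compounds named here.

Measured so far:
compound 1 `O=C(CO[N+](=O)[O-])Nc1ccc(C(=O)/C=C/c2ccc(Cl)cc2)cc1` — 67%
compound 2 `CC(=O)c1ccc(OCC(=O)Nc2ccc(C(=O)/C=C/c3ccc(Cl)cc3)cc2)cc1` — 58%

In a functional assay on the whole organism (strain albino) for inhibition, with Rattus norvegicus as the target, read by paw edema, with stated times of 30 min and 4 h, at a dose of 100 mg/kg by the oral route (a higher number here means more inhibition at the dose given (going by the name of the read-out), a lower number less inhibition), compound 2 stands nearest compound 1, the step of a number 9 percentage points lower from compound 1 to compound 2 (within the scatter) being within the scatter, so the two numbers are not separated. Compound 3 `C/C(=N/O)c1ccc(OCC(=O)Nc2ccc(C(=O)/C=C/c3ccc(Cl)cc3)cc2)cc1` differs from compound 2 by a group of 4 heavy atoms (2 carbon, 1 nitrogen, 1 oxygen; no ring) in place of a group of 3 heavy atoms (2 carbon, 1 oxygen; no ring), on an aromatic carbon. Within the data shown here, no measured step covers a change at this place or of this kind; the one step known, a number 9 percentage points lower from compound 1 to compound 2 (within the scatter), concerns a different part of the molecule and is itself within the scatter. No step beyond the scatter is therefore expected, no change at the digits printed from compound 2 to compound 3 (within the scatter). Compound 3 is estimated at 58%, with a range from 45% to 70%.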

Compound 3, a percentage reported as inhibition, in the whole organism at one dose (the size of the read-out at that dose, not a potency): 55%
Beside the measured number, compound 3's estimate is 3 percentage points above it, within the range that was stated.
By their numbers in this assay, from the lowest: compounds 3, 2 and 1 (each within the scatter of the next, the first and the last beyond it).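

In this assay, the group of 4 heavy atoms in place of acetyl, on an aromatic carbon para to a large group, gives a number 3 percentage points lower from compound 2 to compound 3 (within the scatter) and so brings in a hydrogen-bond donor without a separated change at this dose. Across the other end of the molecule, a number 12 percentage points lower from compound 1 to compound 3 (beyond the scatter) is the first step beyond the scatter, and it is modest. No measured property bears on either step. Going by these compounds, whether an amine or a carboxylic acid on this aromatic carbon would separate from compound 2 remains open.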